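From compound 1 to compound 4: one added methyl

A few compounds are considered here, and "the series" means these few. Any claim that something is new, unique, unknown or untested is made for them only; others in the source may bear on it.

Within the data shown here, in a functional assay on MCF7 cells (Homo sapiens), read by WST assay, with a stated time of 7 days (on this read-out lower numbers stand for an effect already at smaller amounts and higher numbers for an effect only at larger amounts of compound), compound 1 (`C[Si](C)(C)c1ccc(O)cc1`) gives 63 nM, the highest of the three numbers measured so far. Compound 2 (`CCC(CC)(CC)c1ccc(O)cc1`) gives 23 nM and compound 3 (`CC[Si](CC)(CC)c1ccc(O)cc1`) gives 3.4 nM, both lower than compound 1 beyond the scatter. Compound 4 (`CC[Si](C)(C)c1ccc(O)cc1`) remains unmeasured. It differs from compound 1 by methyl in place of hydrogen on a saturated chain carbon bound to a silicon atom. Among the measured compounds shown here, no step at a single place has been measured, so the only guide to direction is the lower number of compound 3 at 3.4 nM. A moderate move to a lower number is expected, an estimated 2.5-fold lower number from compound 1 to compound 4 (0.40 log units; beyond the scatter). For compound 4 the estimated value is 25 nM, with an expected range of 9 nM to 60 nM.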

Compound 4, half-maximal effective concentration in the MCF7 assay: 41 nM
Compound 4: the middle estimate sits 1.6-fold (0.21 log units) below what was measured; measured number inside the range.
By their numbers in the MCF7 assay, from the lowest: compound 3; then compounds 2, 4 and 1 (each within the scatter of the next, the first and the last beyond it).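

In the MCF7 assay, methyl in place of hydrogen on a saturated chain carbon bound to a silicon atom gives a 1.5-fold lower number from compound 1 to compound 4 (0.19 log units; within the scatter), so this single change does not separate the two compounds on that read-out. In a physicochemical assay for lipophilicity, read by HPLC, measured as octanol-water partition (on this read-out lower numbers stand for lower lipophilicity and higher numbers for higher lipophilicity), the same change does register, as a rise in lipophilicity: the measured partition coefficient of compound 1, 4.12, and of compound 4, 4.64, a number 0.52 log units higher (beyond the scatter). In the physicochemical assay compound 1 gives 4.12 and compound 4 gives 4.64. At this position, then, a lipophilicity change of this size comes without a step beyond the scatter in the MCF7 assay.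

Open, as far as these compounds go, is whether a longer chain, such as propyl, or an amine at this same place would move the number in the MCF7 assay beyond the scatter. The compounds shown also do not resolve the distance to compound 3 into single steps.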